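A few compounds are considered here, and "the series" means these few. Any claim that something is new, unique, unknown or untested is made for them only; others in the source may bear on it.

Compound 1 `CSCC[C@H](NC(=O)c1cc(Cl)ccc1OCCNC(=O)OC(C)(C)C)C(=O)Nc1ccc([N+](=O)[O-])cc1Cl` carries a tert-butoxycarbonyl group on an amine nitrogen whose other neighbours are a saturated chain carbon. In a functional assay on MDA-MB-231 cells (Homo sapiens) for inhibition, read by MTT assay, with a stated time of 72 h (a higher number here means a weaker inhibitor, a lower number a stronger inhibitor), compound 1 gives only a limit of the assay, > 10000 nM. Compound 2 `CSCC[C@H](NC(=O)c1cc(Cl)ccc1OCCN)C(=O)Nc1ccc([N+](=O)[O-])cc1Cl` differs from compound 1 by hydrogen in place of tert-butoxycarbonyl on an amine nitrogen. In this assay compound 2 likewise gives a limit, > 10000 nM. The step that the two limits leave unreadable from compound 1 to compound 2 therefore has no readable size, since both values sit at the limit of > 10000 nM in this assay, at which 3 of the 3 values shown sit.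

Compound 3 `CC(C)[C@H](NC(=O)c1cc(Cl)ccc1OCCNC(=O)OC(C)(C)C)C(=O)Nc1ccc(C(F)(F)F)cc1Cl` carries the same tert-butoxycarbonyl group on an amine nitrogen but on a different core; the difference between its core and that of compound 1 is not broken down here. In this assay compound 3 also gives a limit, > 10000 nM.

Compound 4 `CC(C)[C@H](NC(=O)c1cc(Cl)ccc1OCCN)C(=O)Nc1ccc(C(F)(F)F)cc1Cl` has not yet been measured and differs from compound 3 by hydrogen in place of tert-butoxycarbonyl on an amine nitrogen, the same change as that from compound 1 to compound 2, at the same place, on an amine nitrogen whose other neighbours are a saturated chain carbon. Nothing in the measured pair tells how large this change is, and every measured value sits at the limit of > 10000 nM in this assay, at which 3 of the 3 values shown sit, so compound 4 is expected to stay at the limit as well. The step that this expectation means is estimated as a step that the limit leaves unreadable from compound 3 to compound 4. For compound 4 the expected value in this assay is 20000 nM, estimated to lie between 8000 nM and 60000 nM.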

Compound 4, half-maximal inhibitory concentration: 5440 nM
For compound 4 the middle estimate is 3.7-fold (0.57 log units) above the measured one; measured number below the stated range.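

In this assay, putting hydrogen in place of tert-butoxycarbonyl on the amine nitrogen gives an at least 1.8-fold lower number from compound 3 to compound 4 (0.26 log units; that floor lies within the scatter), and compound 4, at 5440 nM, is the only compound shown that has a number rather than a limit. This shows that on the core of compound 3 the change leads from a limit to a readable value, but the step is only a floor, so it does not establish a size beyond the usual scatter. Nor does it show that the change carries from one core to another, since the same change on the core of compound 1 cannot be read, because both of its ends sit at one limit: the limit of > 10000 nM in this assay, at which 3 of the 4 values shown sit.

The compounds shown leave open whether a longer chain bearing the amine, a dimethylamino group or a carboxylic acid at the end of the chain would give a readable value in this assay. They also leave open which part of the core matters, since compound 2 and compound 4 differ in more than one place and cannot be compared as a single change.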